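Chain Lengthening Across Two Related Amide Series

This account rests on a few compounds, and the source may have more. Where it says the series, first, only, none or still open, it means among the compounds named here.

Compound 1 `C/C=C/C=C/C(=O)N[C@H](C(=O)NCCCCCCCC)[C@@H](C)O` and compound 2 `C/C=C/C=C/C(=O)N[C@H](C(=O)NCCCCCCCCCCCC)[C@@H](C)O` share one core, while compound 3 `CCCCCCCCCCCCCCNC(=O)[C@@H](NC(=O)c1ccccc1)[C@@H](C)O` and compound 4 `CCCCCCCCCCCCCCCCCCNC(=O)[C@@H](NC(=O)c1ccccc1)[C@@H](C)O` share another; the difference between the two cores is not broken down here. In a functional assay on A-431 cells (Homo sapiens) for cytotoxicity, read by MTT assay, with a stated time of 48 h (a lower number here means a stronger inhibitor, a higher number a weaker inhibitor), compound 1 gives 58200 nM, compound 2 gives 171000 nM and compound 3 gives 118000 nM. The change from compound 1 to compound 2, (butyl in place of hydrogen on a saturated chain carbon, eight bonds along the chain from an amide-type nitrogen), made the step of a 2.9-fold higher number from compound 1 to compound 2 (0.47 log units; beyond the scatter). The change from compound 3 to compound 4 is butyl in place of hydrogen on a saturated chain carbon, ten or more bonds along the chain from an amide-type nitrogen; it is the same kind of change, but it sits at a different place along the chain and on a different core. Compound 4 is expected to show the step of a 2.5-fold higher number from compound 3 to compound 4 (0.41 log units; beyond the scatter), resting on a single earlier step of this kind, because a 2.9-fold higher number from compound 1 to compound 2 (0.47 log units; beyond the scatter) pointed toward weaker inhibition. Compound 4 is therefore estimated at 300000 nM, most likely between 150000 nM and 650000 nM.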

Compound 4, half-maximal inhibitory concentration: 113000 nM
Compound 4: the middle estimate sits 2.7-fold (0.42 log units) above what was measured; measured number outside the range, below it.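

In this assay the butyl change gave a 1.0-fold lower number from compound 3 to compound 4 (0.02 log units; within the scatter) and so made no clear difference on this core. The change did not carry over from one core to the other with the same size: the same change on two cores in this assay, a 2.9-fold higher number (0.47 log units; beyond the scatter) from compound 1 to compound 2 and a 1.0-fold lower number (0.02 log units; within the scatter) from compound 3 to compound 4, 3.1-fold (0.49 log units) apart, beyond the scatter of two such steps. Among these compounds, this shows that a step seen on one core cannot simply be assumed on the other, but it does not show why, as the core and the place along the chain both differ, and each core offers only one step.

From the compounds shown here alone, it remains open how a still longer chain would behave on either core. An amine or a carboxylic acid at the chain end could also give a different result.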